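The compounds below may be only part of what the source reports. "The series", "measured", "known", "first", "only" and "open" are said of these compounds alone.

Working notes on the series around the shared core of compound 1 `CCN1CCN(CCC(=O)Nc2nc3c(C)cccc3s2)CC1`. In an assay on membranes from brain for displacement of a labelled ligand from Sigma non-opioid intracellular receptor 1 (Cavia porcellus), read by scintillation counting, with a stated time of 120 min (on this read-out lower numbers stand for stronger inhibition and higher numbers for weaker inhibition), compound 1 gives 543 nM. Compound 2 `Cc1cccc2sc(NC(=O)CCN3CCN(C(C)C)CC3)nc12` gives 1300 nM in this assay, the highest number of the three measured; the step of a 2.4-fold higher number from compound 1 to compound 2 (0.38 log units; beyond the scatter) is modest. Compound 3 `Cc1cccc2sc(NC(=O)CCN3CCN(CCN(C)C)CC3)nc12` gives 1000 nM; the steps of a 1.8-fold higher number from compound 1 to compound 3 (0.27 log units; within the scatter) and a 1.3-fold lower number from compound 2 to compound 3 (0.11 log units; within the scatter) both stay within the scatter, so compound 2 and compound 3 cannot be ordered against each other.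

The next compound, compound 4 `Cc1cccc2sc(NC(=O)CCN3CCN(c4ccccn4)CC3)nc12`, differs from compound 2 as follows: pyridin-2-yl in place of isopropyl on an amine nitrogen in a ring. Among the compounds with values here, two measured steps touch the same amine nitrogen in a ring, but neither puts an aromatic group there: the step from isopropyl to 2-(dimethylamino)ethyl, a 1.3-fold lower number from compound 2 to compound 3 (0.11 log units; within the scatter), stays within the scatter, and the step that adds the methyl, a 2.4-fold higher number from compound 1 to compound 2 (0.38 log units; beyond the scatter), is modest. Within the data shown here, no measured step covers a pyridin-2-yl group, so the direction is uncertain; a change no larger than modest is expected, if anything toward a lower number. Compound 4 is therefore estimated at 900 nM in this assay, with a range from 300 nM to 2700 nM, meaning an expected step of a 1.4-fold lower number from compound 2 to compound 4 (0.16 log units; within the scatter).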

Compound 4, inhibition constant: 1000 nM
Beside the measured number, compound 4's estimate is 1.1-fold (0.05 log units) below it, and the stated range covers the measured number.
By their numbers in this assay, from the lowest: compounds 1, 3, 4 and 2 (each within the scatter of the next, the first and the last beyond it).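

In this assay, within the data shown here, pyridin-2-yl puts an aromatic ring on the amine nitrogen in a ring for the first time, and the result stays within the scatter of all three chain-bearing compounds (a 1.3-fold lower number from compound 2 to compound 4 (0.11 log units; within the scatter); no change at the digits printed from compound 3 to compound 4 (within the scatter); a 1.8-fold higher number from compound 1 to compound 4 (0.27 log units; within the scatter)). This position therefore accepts a six-membered aromatic ring with 1 hetero atom without a step beyond the scatter, and compound 2, compound 3 and compound 4 cannot be ordered against each other. No supporting data bear on the reason for this result.

A phenyl or benzyl group on this nitrogen would show whether the ring nitrogen of pyridin-2-yl plays any part in the number, which these compounds cannot tell. On these data alone, how a carboxylic acid at the end of a longer chain would fare at this position also remains open.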